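Replacing Trimethoxyphenyl with a Hydroxy-Methoxyphenyl Group

The compounds below may be only part of what the source reports. "The series", "measured", "known", "first", "only" and "open" are said of these compounds alone.

Of the compounds shown here, three sharing one core have been measured in a functional assay on U-87MG ATCC cells (Homo sapiens) for cytotoxicity, read by MTT assay, with a stated time of 72 h; a lower number here means a stronger inhibitor, a higher number a weaker inhibitor. Compound 1 `CN(C)CCn1cnnc1-c1cc(Oc2ccc(NC(=O)N/N=C/c3cc(C(C)(C)C)cc(C(C)(C)C)c3O)cc2F)ccn1` gives 520 nM, the lowest number of the three. Compound 2 `CN(C)CCn1cnnc1-c1cc(Oc2ccc(NC(=O)N/N=C/c3ccccc3)cc2F)ccn1` gives 2250 nM. Compound 3 `COc1cc(/C=N/NC(=O)Nc2ccc(Oc3ccnc(-c4nncn4CCN(C)C)c3)c(F)c2)cc(OC)c1OC` gives 22500 nM, the highest number: its nearest neighbour is compound 2 and its furthest is compound 1, both separated from it by more than the usual scatter.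

Compound 4 `COc1cc(/C=N/NC(=O)Nc2ccc(Oc3ccnc(-c4nncn4CCN(C)C)c3)c(F)c2)ccc1O` has not yet been measured. Its difference from compound 3 is 4-hydroxy-3-methoxyphenyl in place of 3,4,5-trimethoxyphenyl on a carbon with a double bond to nitrogen.

For the measured compounds named here, only one measured step speaks to this change. It is a 10-fold higher number from compound 2 to compound 3 (1.00 log units; beyond the scatter), which shows that adding three methoxy groups to a bare phenyl weakened the compound. Compound 4 removes one of those methoxy groups and puts a hydroxyl in its place, moving partway back toward compound 2. Going by the values given here, compound 1, which carries a hydroxyl on its own aryl group, gives the lowest number in this assay, though no single step links it to compound 3.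

On that basis a modest improvement is expected for compound 4, estimated as a 2.8-fold lower number from compound 3 to compound 4 (0.45 log units; beyond the scatter), giving an expected value of 8000 nM with a range from 2500 nM to 25000 nM.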

Compound 4, half-maximal inhibitory concentration: > 100000 nM
Compound 4: no number, only a limit; the forecaster's own chance of this, stated with the estimate: 5%; at least 12-fold (1.09 log units) between middle value and limit.
By their numbers in this assay, from the lowest: compound 1; then compound 2; then compound 3. At a limit, above all of these: compound 4.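

In this assay compound 4 gives > 100000 nM, which is a limit of the assay and not a number. Taking away methoxy groups and adding a hydroxyl did not move the compound back toward bare phenyl: 4-hydroxy-3-methoxyphenyl in place of 3,4,5-trimethoxyphenyl brings an at least 4.4-fold higher number from compound 3 to compound 4 (0.64 log units; beyond the scatter), and against the bare phenyl the same group shows an at least 44-fold higher number from compound 2 to compound 4 (1.64 log units; beyond the scatter). So, on a carbon with a double bond to nitrogen, the substituted aryl groups shown do not fall in a simple order by how many methoxy groups they carry, and a hydroxyl on the aryl group does not by itself go with a low number, since compound 1 also carries one and still has the lowest number of the series.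

The compounds shown do not tell whether the hydroxyl, the loss of a methoxy group or the particular pattern of the two drives this step, and a phenyl carrying only a hydroxyl or only a single methoxy group would separate these. Nor do they show how an amine or a carboxylic acid in place of the hydroxyl would behave in this assay.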